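Trimming the alkyl chain on the shared core: compound 4

This account rests on a few compounds, and the source may have more. Where it says the series, first, only, none or still open, it means among the compounds named here.

Compound 1 `CC(=N)N1CCC(Oc2ccc3ncn(Cc4ccc5ccc(C(=N)N)cc5c4)c3c2)CC1` gives 50 nM in an assay on isolated protein for inhibition of serine protease 1 (Bos taurus); a higher number here means a weaker inhibitor, a lower number a stronger inhibitor.
Compound 2 `CCCCc1nc2cc(OC3CCN(C(C)=N)CC3)ccc2n1Cc1ccc2ccc(C(=N)N)cc2c1` gives 14 nM in this assay.
Compound 3 `CC(=N)N1CCC(Oc2ccc3nc(C)n(Cc4ccc5ccc(C(=N)N)cc5c4)c3c2)CC1` gives 18 nM in this assay.

Among the three measured compounds, compound 2 has the lowest number; its gap to compound 3 lies within the scatter, while its gap to compound 1 lies beyond it. Compound 4 `CCc1nc2cc(OC3CCN(C(C)=N)CC3)ccc2n1Cc1ccc2ccc(C(=N)N)cc2c1` has not yet been measured. It differs from compound 2 by hydrogen in place of ethyl on a saturated chain carbon, two bonds along the chain from an aromatic carbon, so the butyl of compound 2 becomes an ethyl. Among the measured compounds shown here, the one measured step that bears on the length of this chain is a 2.8-fold lower number from compound 1 to compound 3 (0.44 log units; beyond the scatter), and the values of compound 2 and compound 3 show that going from methyl to butyl adds nothing beyond the scatter. An ethyl sits between those two chains, so no step beyond the scatter is expected; compound 4 is estimated at 16 nM (range 8 nM to 35 nM), which would mean an expected 1.1-fold higher number from compound 2 to compound 4 (0.06 log units; within the scatter).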

Compound 4, inhibition constant: 17 nM
Estimate against measurement, compound 4: 1.1-fold (0.03 log units) below; low and high end bracket the measured number.
By their numbers in this assay, from the lowest: compounds 2, 4 and 3 (each within the scatter of the next); then compound 1.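

Shortening the butyl to an ethyl gives a 1.2-fold higher number from compound 2 to compound 4 (0.08 log units; within the scatter) in this assay, so this change at the saturated chain carbon, two bonds along the chain from an aromatic carbon, has now been measured directly as a step within the scatter. With compound 3 at 18 nM and compound 4 at 17 nM also within the scatter of each other, the methyl, ethyl and butyl chains cannot be told apart in this assay, and the step beyond the scatter remains the one from hydrogen to methyl, a 2.8-fold lower number from compound 1 to compound 3 (0.44 log units; beyond the scatter). No measurement shown here explains this flat response to chain length.

Going by these compounds, it remains open whether a chain longer than butyl, or a branched chain such as isopropyl, would stay within this range. The same holds for a chain ending in an amine or a carboxylic acid.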